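The source may hold more compounds than are shown below. What is called first, only, known or untested is meant among the compounds shown, and "the series" means these compounds.

Three measured compounds share one core and differ only in the ring group on a carbonyl carbon. In a functional assay on HepG2 cells (Homo sapiens) for inhibition, read by MTT assay (a higher number here means a weaker inhibitor, a lower number a stronger inhibitor), compound 1 `COc1cc2ncnc(Nc3ccc(NC(=O)c4ccc(C)cc4)cc3)c2cc1OC` gives 25000 nM, compound 2 `COc1cc2ncnc(Nc3ccc(NC(=O)c4cccc(F)c4)cc3)c2cc1OC` gives 8200 nM and compound 3 `COc1cc2ncnc(Nc3ccc(NC(=O)c4ccccc4Cl)cc3)c2cc1OC` gives 26000 nM. Compound 3 therefore sits with compound 1 at the high-number, weaker end of this small set, and the step of a 1.0-fold higher number from compound 1 to compound 3 (0.02 log units; within the scatter) lies within the scatter.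

The unmeasured compound 4 `COc1cc2ncnc(Nc3ccc(NC(=O)c4cccc(C(F)(F)F)c4)cc3)c2cc1OC` has 3-(trifluoromethyl)phenyl in place of 2-chlorophenyl on a carbonyl carbon. Two modest measured steps bear on this change: a 3.0-fold lower number from compound 1 to compound 2 (0.48 log units; beyond the scatter) and a 3.2-fold higher number from compound 2 to compound 3 (0.50 log units; beyond the scatter). The nearest guide by group name is compound 2 at 8200 nM, so a modest drop in the number is expected in this assay. Three compounds are thin ground, however, and a result within the scatter would not surprise. The estimated change is a 2.2-fold lower number from compound 3 to compound 4 (0.34 log units; beyond the scatter). For compound 4 the expected value is 12000 nM, with an estimated range of 4500 nM to 28000 nM.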

Compound 4, half-maximal inhibitory concentration: 83000 nM
Estimate against measurement, compound 4: 6.9-fold (0.84 log units) below; measured number outside the range, above it.
By their numbers in this assay, from the lowest: compound 2; then compounds 1 and 3 (each within the scatter of the next); then compound 4.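

In this assay, among these compounds, the ring group on the carbonyl carbon can raise the number well beyond the range of the earlier compounds, as a 3.2-fold higher number from compound 3 to compound 4 (0.50 log units; beyond the scatter) and a 3.3-fold higher number from compound 1 to compound 4 (0.52 log units; beyond the scatter) show, making compound 4 the weakest inhibitor of the four. Trifluoromethyl in place of fluoro on an aromatic carbon gives the only large step in the set, a 10-fold higher number from compound 2 to compound 4 (1.01 log units; beyond the scatter), so 3-fluorophenyl and 3-(trifluoromethyl)phenyl mark its two ends despite their similar names. Nothing shown here explains why this change weakens inhibition so strongly.

Still open, on these data alone, is how a phenyl ring carrying a nitrile, a carboxylic acid or an amine would read. With only four compounds, it is also unclear whether other groups would fall inside this range or beyond it.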